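The source may report more compounds than this note shows. Statements on the series, on what has been measured and on what is new or still open speak of the compounds shown alone.

Of the compounds shown here, three of one family have been tested in a functional assay on MIA PaCa-2 cells (Homo sapiens) for cytotoxicity, read by WST assay, with a stated time of 24 h; on this read-out higher numbers stand for weaker inhibition and lower numbers for stronger inhibition. Compound 1 `N#C/C(=C\c1c[nH]c2cc(F)ccc12)C(=O)c1c[nH]c2ccccc12` gives 23500 nM. Compound 2 `COc1ccc2c(C(=O)/C(C#N)=C/c3c[nH]c4cc(F)ccc34)c[nH]c2c1` gives only a limit of the assay, > 50000 nM. Compound 3 `COc1ccc2c(C(=O)/C(C#N)=C/c3c[nH]c4ccc(OC)cc34)c[nH]c2c1` likewise gives only a limit, > 50000 nM. Compound 2 and compound 1 differ in one place: hydrogen in place of methoxy on an aromatic carbon. This change produced an at least 2.1-fold lower number from compound 2 to compound 1 (0.32 log units; beyond the scatter); the step can be given only as a lower bound due to the limit of > 50000 nM in this assay, at which 2 of the 3 values shown sit. How the core of compound 2 differs from the core of compound 3 is not broken down here.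

Compound 4 `COc1ccc2c(C(=O)/C(C#N)=C/c3c[nH]c4ccccc34)c[nH]c2c1` has not yet been measured. It differs from compound 3 by the same change: hydrogen in place of methoxy on an aromatic carbon. In this assay the step from compound 3 to compound 4 is expected to be an at least 1.1-fold lower number from compound 3 to compound 4 (0.04 log units; that floor lies within the scatter), an expectation resting on the measured step of the same change, an at least 2.1-fold lower number from compound 2 to compound 1 (0.32 log units; beyond the scatter). Since compound 3 stands at a limit, the starting point of that step is itself uncertain. Compound 4 is therefore expected to give about 45000 nM, most likely between 18000 nM and 120000 nM, with a real chance that only a limit is reported again.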

Compound 4, half-maximal inhibitory concentration: 13500 nM
Compound 4: middle estimate off by 3.3-fold (0.52 log units), on the high side, outside the stated range (below it).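

In this assay, hydrogen in place of methoxy gives an at least 3.7-fold lower number from compound 3 to compound 4 (0.56 log units; beyond the scatter), so the direction of the earlier step holds on a second core: the same change on two cores in this assay, an at least 2.1-fold lower number (0.32 log units; beyond the scatter) from compound 2 to compound 1 and an at least 3.7-fold lower number (0.56 log units; beyond the scatter) from compound 3 to compound 4; the limit leaves it open whether they differ
Hydrogen in place of fluoro gives an at least 3.7-fold lower number from compound 2 to compound 4 (0.56 log units; beyond the scatter), a step that also points towards a lower number.
Both steps start from compounds that give only a limit rather than a number, so their true sizes stay unknown, and two cores do not make a rule for the whole series: the limit of > 50000 nM in this assay, at which 2 of the 4 values shown sit.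

The compounds shown leave open how a hydroxyl, an amine or a carboxylic acid would fare on the same aromatic carbon in place of methoxy. Also open, on these data alone, is how the number responds to a change at the nitrile or the carbonyl, both of which all four compounds share.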